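The source may hold more compounds than are shown below. What is called first, only, known or untested is meant among the compounds shown, and "the series" means these compounds.

Working notes on the series. In a functional assay on HL-60 cells (Homo sapiens) for inhibition (on this read-out lower numbers stand for stronger inhibition and higher numbers for weaker inhibition), compound 1 (`COc1c([N+](=O)[O-])cc(/C=C\c2ccc3ccccc3c2)cc1[N+](=O)[O-]`) gives > 5000 nM as a limit and not a number. Compound 2 (`CN(C)c1c([N+](=O)[O-])cc(/C=C/c2ccc3ccccc3c2)cc1[N+](=O)[O-]`) gives > 5000 nM as a limit as well, so it has no number of its own. Both values shown sit at the same limit (the limit of > 5000 nM in this assay, at which 2 of the 2 values shown sit) and neither can be ranked against the other.

The next compound is compound 3 (`CN(C)c1c([N+](=O)[O-])cc(/C=C\c2ccc3ccccc3c2)cc1[N+](=O)[O-]`), and the change from compound 2 is purely one of geometry: the two compounds have the same atoms and bonds and differ only in configuration as drawn: 1 of 1 stereo elements differ; a double bond is drawn E in compound 2 and Z in compound 3. The atoms and bonds stay the same, and a double bond is drawn E in compound 2 and Z in compound 3. Among the compounds with values here, no measured pair shows a step of this kind, so its size cannot be read from the data. Since compound 2 has only a limit, any measurable change in this assay could only be towards stronger inhibition. The step of an at least 1.2-fold lower number from compound 2 to compound 3 (0.09 log units; that floor lies within the scatter) is expected to be modest and in that direction, if it appears at all. For compound 3 the estimated value is 4000 nM with an expected range of 500 nM to 10000 nM, and another limit remains quite possible.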

Compound 3, half-maximal inhibitory concentration: 2750 nM
The estimate for compound 3 lay 1.5-fold (0.16 log units) above the measured number; low and high end bracket the measured number.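

In this assay, within the data shown here, compound 3 gives 2750 nM, the only number so far, and it carries dimethylamino on the aromatic carbon together with a double bond drawn Z. Changing the double bond from E to Z gives an at least 1.8-fold lower number from compound 2 to compound 3 (0.25 log units; that floor lies within the scatter), so the series now holds a first reading on geometry, with nothing else changed between the two compounds: the fact that compounds 2 and 3 differ only in the configuration as drawn. Among these compounds, with the double bond drawn Z in both compounds, dimethylamino in place of methoxy on an aromatic carbon gives an at least 1.8-fold lower number from compound 1 to compound 3 (0.25 log units; that floor lies within the scatter), which is a first reading on this position as well.

Going by these compounds, the true size of both steps stays open, since each rests on a limit and each printed floor is only a lower bound: the limit of > 5000 nM in this assay, at which 2 of the 3 values shown sit. Also open, on these data alone, is whether a primary amine or a morpholine in place of dimethylamino on the same carbon, with the double bond drawn Z, would move the number any further from that of compound 3.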